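Swapping a Sulfamoyl Amine for a Sulfopropyl Amine

The compounds below may be only part of what the source reports. "The series", "measured", "known", "first", "only" and "open" are said of these compounds alone.

Compound 1, `NC[C@@H]1CCCc2cc(S(=O)(=O)c3cccc(O)c3)ccc21`: 0.251 nM
Compound 2, `NC[C@@H]1CCCc2cc(S(=O)(=O)c3c[nH]c4ccccc34)ccc21`: 0.0501 nM
Compound 3, `CN(C[C@@H]1CCCc2cc(S(=O)(=O)c3cccc(F)c3)ccc21)S(N)(=O)=O`: 3.98 nM

Of the compounds shown here, three built on the shared core have been tested in an assay on isolated protein for displacement of a labelled ligand from 5-hydroxytryptamine receptor 6 (Homo sapiens); on this read-out lower numbers stand for stronger inhibition and higher numbers for weaker inhibition. Compound 3 stands highest of the three numbers. Its nearest neighbour is compound 1, which gives a lower number, and the gap lies beyond the scatter. Compound 2 is furthest away, with a lower number still, again beyond the scatter. Compounds 1 and 2 carry a plain amine on the chain carbon, whereas compound 3 carries a substituted one, and that is where the next change is made.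

Compound 4, `O=S(=O)(O)CCCNC[C@@H]1CCCc2cc(S(=O)(=O)c3cccc(F)c3)ccc21`, differs from compound 3 in one place: (3-sulfopropyl)amino in place of methyl(sulfamoyl)amino on a saturated chain carbon bound to a saturated ring carbon. The fluorine on the phenyl ring and the rest of the core stay as they are.

For the measured compounds named here, no measured pair shows this exact change, so the expectation rests on the surrounding numbers. Because compound 1 gives 0.251 nM with an unsubstituted amine, a modest move toward lower numbers is expected, and the step from compound 3 to compound 4 is estimated as a 2.0-fold lower number from compound 3 to compound 4 (0.30 log units; within the scatter). Compound 4 is therefore expected to read 2 nM, with a range from 0.3 nM to 12 nM.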

Compound 4, inhibition constant: 1.26 nM
Compound 4: the middle estimate sits 1.6-fold (0.20 log units) above what was measured, and the stated range covers the measured number.
By their numbers in this assay, from the lowest: compound 2; then compound 1; then compound 4; then compound 3.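

In this assay, putting (3-sulfopropyl)amino in place of methyl(sulfamoyl)amino on a saturated chain carbon bound to a saturated ring carbon gives a 3.2-fold lower number from compound 3 to compound 4 (0.50 log units; beyond the scatter), a modest step. This is the first pair shown in which only this position changes, with the fluorine on the phenyl ring and the rest of the core held fixed. The entering group has more heavy atoms and more hydrogen-bond donors and acceptors than the group it replaces, yet the number falls rather than rises, and nothing available here explains the shift.

Still open, from the compounds shown here alone, is how a plain amine would read on the core of compound 3 with its fluorine on the phenyl ring, a single change that would connect this pair more directly to the low numbers of compound 1 and compound 2. Also open, going by these compounds, is whether the sulfonic acid end or the propyl chain carries the step, a question that a carboxylic acid at the end of the chain, or a shorter or longer chain, would address.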